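Tetrazole versus methylpyrazole on the benzyl arm of the urea

The source may report more compounds than this note shows. Statements on the series, on what has been measured and on what is new or still open speak of the compounds shown alone.

Measured compounds, read-out in an assay on microsomes from intestine for inhibition of acyl-CoA:cholesterol acyltransferase (Oryctolagus cuniculus); on this read-out lower numbers stand for stronger inhibition and higher numbers for weaker inhibition:
- compound 1 `Cc1cc(C)c(NC(=O)N(Cc2cccc(-c3nn[nH]n3)c2)C2CCCCCC2)c(C)c1`: > 1000 nM, a limit of the assay, not a number
- compound 2 `Cc1cc(C)c(NC(=O)N(Cc2ccc(N3CCN(C)CC3)cc2)C2CCCCCC2)c(C)c1`: 57 nM
- compound 3 `Cc1cc(C)c(NC(=O)N(Cc2ccc(-c3cccnc3)cc2)C2CCCCCC2)c(C)c1`: 130 nM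

Compound 1 sits at the limit (the limit of > 1000 nM in this assay, at which 1 of the 3 values shown sits), the weakest position among the three compounds, with no number behind it. Among the compounds with values here, compound 2 and compound 3 carry their substituents at a different point of the benzyl ring, and the one measured step, a 2.3-fold higher number from compound 2 to compound 3 (0.36 log units; beyond the scatter), exchanges two groups unrelated to the change considered here.

Compound 4 `Cc1cc(C)c(NC(=O)N(Cc2cccc(-c3ccnn3C)c2)C2CCCCCC2)c(C)c1` differs from compound 1 by 1-methyl-1H-pyrazol-5-yl in place of 2H-tetrazol-5-yl on an aromatic carbon. Within the data shown here, no measured step bears directly on this exchange. Among the measured compounds shown here, the only guidance is that compound 3 shows a five- or six-membered heteroaryl at the benzyl ring can sit at 130 nM. Compound 1, carrying the tetrazole, gives only a limit of the assay. The step of an at least 4.0-fold lower number from compound 1 to compound 4 (0.60 log units; beyond the scatter) is therefore expected to run toward stronger inhibition, with wide uncertainty. For compound 4 the estimate in this assay is 250 nM, between 50 nM and 2000 nM.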

Compound 4, half-maximal inhibitory concentration: 35 nM
Compound 4: the middle estimate sits 7.1-fold (0.85 log units) above what was measured, outside the stated range (below it).
By their numbers in this assay, from the lowest: compounds 4 and 2 (each within the scatter of the next); then compound 3. At a limit, above all of these: compound 1.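

In this assay, the exchange gives an at least 28-fold lower number from compound 1 to compound 4 (1.45 log units; beyond the scatter). The place meta to a large group can therefore carry a five-membered aromatic ring with strong inhibition, and the poor result for compound 1 belongs to the tetrazole rather than to the place itself. Compound 1 stands at a limit, so this step has one open end and its true size cannot be read: the limit of > 1000 nM in this assay, at which 1 of the 4 values shown sits.

The exchange removes the hydrogen-bond donor, reduces the hetero atoms in the ring and adds a methyl all at once, and the compounds shown do not separate these changes. On these data alone, it also stays open whether a carboxylic acid or the unmethylated 1H-pyrazol-5-yl at this place would follow the tetrazole or the methylpyrazole, and what moving 1-methyl-1H-pyrazol-5-yl to another ring carbon would do.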